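One Group Exchanged on a Sulfur Side Chain

A few compounds are considered here, and "the series" means these few. Any claim that something is new, unique, unknown or untested is made for them only; others in the source may bear on it.

In a functional assay on HepG2 cells (Homo sapiens) for inhibition, read by MTT assay, with a stated time of 48 h (a higher number here means a weaker inhibitor, a lower number a stronger inhibitor), compound 1 `COc1ccc(-n2c(S)nnc2-c2cc(OC)c(OC)c(OC)c2)cc1`, which has a hydrogen on its sulfur, gives 57500 nM. Compound 2 `COc1ccc(-n2c(SCc3ccccc3)nnc2-c2cc(OC)c(OC)c(OC)c2)cc1`, with benzyl on that sulfur, is reported only as a limit of the assay, > 60000 nM. This limit leaves an at least 1.0-fold higher number from compound 1 to compound 2 (0.01 log units; that floor lies within the scatter). Compound 3 `COc1ccc(C(=O)CSc2nnc(-c3cc(OC)c(OC)c(OC)c3)n2-c2ccc(OC)cc2)cc1`, with ((4-methoxyphenyl)carbonyl)methyl on the sulfur, gives 18100 nM, the lower of the two actual numbers and the best result so far. Against the limit, this is an at least 3.3-fold lower number from compound 2 to compound 3 (0.52 log units; beyond the scatter).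

Compound 4 `COc1ccc(-n2c(SCC(=O)Nc3ccc(Cl)cc3)nnc2-c2cc(OC)c(OC)c(OC)c2)cc1` keeps the carbonyl, but (4-chlorophenyl)amino stands in place of 4-methoxyphenyl on the carbonyl carbon: (4-chlorophenyl)amino in place of 4-methoxyphenyl on a carbonyl carbon. Among the compounds with values here, no measured step makes this exact exchange. The closest evidence is the change of the whole sulfur group, which gave a 3.2-fold lower number from compound 1 to compound 3 (0.50 log units; beyond the scatter) and so only a modest step for compound 3. Compound 4 differs from compound 3 in just part of that group, so no step beyond the scatter is expected in this assay, although either direction remains possible. The estimated step is a 1.1-fold lower number from compound 3 to compound 4 (0.05 log units; within the scatter). Compound 4 is expected at about 16000 nM, with an estimated range of 5000 nM to 50000 nM.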

Compound 4, half-maximal inhibitory concentration: > 60000 nM
Compound 4: a limit, no number; the forecaster's own chance of this, stated with the estimate: 12%; at least 3.7-fold (0.57 log units) between middle value and limit.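

In this assay the group on the carbonyl carbon proves to matter: (4-chlorophenyl)amino in place of 4-methoxyphenyl gives an at least 3.3-fold higher number from compound 3 to compound 4 (0.52 log units; beyond the scatter) even though the two groups have the same count of heavy atoms and each holds one six-membered aromatic ring. Placing the whole ((4-chlorophenyl)carbamoyl)methyl group on the sulfur in place of hydrogen gives only an at least 1.0-fold higher number from compound 1 to compound 4 (0.01 log units; that floor lies within the scatter) and thus shows no gain, so a carbonyl in the sulfur side chain does not by itself bring the lower number seen with compound 3. Compound 4 is reported only as a limit and not as a number, as is compound 2, so the step between these two cannot be read: the limit of > 60000 nM in this assay, at which 2 of the 4 values shown sit.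

This exchange alters two things at once, the amino link to the carbonyl and the substituent on the ring, so the shown compounds cannot tell which of them accounts for the rise. From the compounds shown here alone, a (4-methoxyphenyl)amino group or a 4-chlorophenyl group on the same carbonyl carbon would separate the two, and how a carboxylic acid at that place would behave also remains open.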